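This account rests on a few compounds, and the source may have more. Where it says the series, first, only, none or still open, it means among the compounds named here.

Measured so far in a functional assay on U-251 cells (Homo sapiens) for cytotoxicity, read by sulforhodamine B assay, with a stated time of 48 h; a lower number here means that less compound is tolerated, a higher number that more compound is tolerated:
compound 1, `ClCc1cccc(Cn2cnc3c(Cl)ncnc32)c1`, gives 6760 nM;
compound 2, `ClCc1cccc(Cn2cnc3c(Cl)nc(Cl)nc32)c1`, gives 5620 nM;
compound 3, `ClCc1ccccc1Cn1cnc2ncnc(Cl)c21`, gives 10200 nM.

From compound 1 to compound 2 the change is chloro in place of hydrogen on an aromatic carbon, and it made a 1.2-fold lower number from compound 1 to compound 2 (0.08 log units; within the scatter). Compound 3 has the same atoms as compound 1 joined differently; the difference between the two cores is not broken down here, and the value of compound 3 lies within the usual scatter of the values of compound 1 and compound 2. Compound 4, `ClCc1ccccc1Cn1cnc2nc(Cl)nc(Cl)c21`, has not yet been measured in this assay. It differs from compound 3 by chloro in place of hydrogen on an aromatic carbon, the same change as that from compound 1 to compound 2, with the place described in the same words. Because a 1.2-fold lower number from compound 1 to compound 2 (0.08 log units; within the scatter) stayed within the scatter, compound 4 is expected to show a step of similar size, estimated as a 1.2-fold lower number from compound 3 to compound 4 (0.08 log units; within the scatter). This expectation rests on a single earlier instance of the change, made on a different core. For compound 4 in this assay the estimated value is 8500 nM, with a likely range from 4000 nM to 18000 nM.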

Compound 4, concentration lethal to 50% of the cells: 3630 nM
Beside the measured number, compound 4's estimate is 2.3-fold (0.37 log units) above it, outside the stated range (below it).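

In this assay, chloro in place of hydrogen on an aromatic carbon, between two ring nitrogen atoms, gave a 2.8-fold lower number from compound 3 to compound 4 (0.45 log units; beyond the scatter), a modest step on the core of compound 3. Set beside the earlier instance of the change, the result gives no firm sign that the core alters the step: the same change on two cores in this assay, a 1.2-fold lower number (0.08 log units; within the scatter) from compound 1 to compound 2 and a 2.8-fold lower number (0.45 log units; beyond the scatter) from compound 3 to compound 4, 2.3-fold (0.37 log units) apart, within the scatter of two such steps

This pair of steps shows that the change lowered the number on one core by a margin beyond the scatter and left it within the scatter on the other, yet the gap between them cannot be told apart from scatter. It does not show that the step has a fixed size across cores, nor that the two cores behave alike, since two pairs are too few to settle either point.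

Still open, going by these compounds, is how an amine or a methoxy group on the same ring carbon would compare with chloro in this assay. Also open, on these data alone, is whether any such replacement would follow the same course on both cores.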